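The compounds below may be only part of what the source reports. "The series", "measured", "known", "first", "only" and "open" are said of these compounds alone.

Of the compounds shown here, two sharing a single core have been measured so far. Compound 1 `CCCC1=C(OCCC(C)C)C(CCC)(CCC)C(=O)/C(=C(O)\C=C\c2ccccc2)C1=O` gives, in a functional assay on KB cells (Homo sapiens) for antiproliferative activity, read by sulforhodamine B assay, with a stated time of 3 days (a lower number here means that less compound is needed, a higher number that more compound is needed for the effect), a value of 10.6 uM. Compound 2 `CCCC1=C(OCC(C)C)C(CCC)(CCC)C(=O)/C(=C(O)\C=C\c2ccccc2)C1=O`, which carries a shorter ether chain, gives in this assay a value of 4.8 uM. Among the two numbers, compound 2 therefore stands lowest, meaning the smaller amount is needed, and the only step recorded, a 2.2-fold lower number from compound 1 to compound 2 (0.34 log units; beyond the scatter), shows that trimming the ether chain by one carbon went together with a lower number.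

Compound 3 `CCCOC1=C(CCC)C(=O)/C(=C(O)/C=C/c2ccccc2)C(=O)C1(CCC)CCC` has not yet been measured. It differs from compound 2 in one place: hydrogen in place of methyl on a saturated chain carbon bound to two saturated chain carbons. Once more a single carbon is removed from the ether chain, though at a different point than before, so the earlier step is a guide only in kind, not a repeat of the same change. Since that earlier step was modest, a further modest lowering, or no step beyond the scatter, seems the fairest expectation. The step from compound 2 is estimated as a 1.4-fold lower number from compound 2 to compound 3 (0.14 log units; within the scatter). Compound 3 is expected to give about 3.5 uM in this assay, most likely between 1.5 uM and 8 uM.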

Compound 3, concentration for half-maximal effect: 2.7 uM
The estimate for compound 3 lay 1.3-fold (0.11 log units) above the measured number, within the range that was stated.
By their numbers in this assay, from the lowest: compounds 3 and 2 (each within the scatter of the next); then compound 1.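

In this assay, removing this one methyl gives a 1.8-fold lower number from compound 2 to compound 3 (0.25 log units; within the scatter) and so does not separate the isobutoxy chain of compound 2 from the propoxy chain of compound 3, even though the numbers for both are low within this small set. The new information lies in the wider comparison: a 3.9-fold lower number from compound 1 to compound 3 (0.59 log units; beyond the scatter) is a larger step than any seen before compound 3 was added, and it stands clearly beyond the scatter, so the ether chain of compound 1 and the propoxy chain of compound 3 can be told apart in this assay. Nothing measured here accounts for these differences in the numbers.

All three compounds fit a lower number with a shorter or less branched ether chain, but this rests on only three chains, and one of the two steps leading to compound 3 cannot be separated from the scatter. Still open, on these data alone, is whether a shorter ethoxy or methoxy group would carry the trend further, and what an amine or a carboxylic acid at the end of the ether chain would do to the number.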